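The source may hold more compounds than are shown below. What is called first, only, known or untested is meant among the compounds shown, and "the series" means these compounds.

Of the compounds shown here, three sharing one core have been measured in a functional assay (Pituitary gland cell) with Rattus norvegicus as the target; on this read-out higher numbers stand for an effect only at larger amounts of compound and lower numbers for an effect already at smaller amounts. Compound 1 `CC(C)(N)CC(=O)N[C@@H]1CCc2ccccc2N(Cc2ccc(-c3ccccc3C(=O)O)cc2)C1=O` gives 2500 nM, compound 2 `CC(C)(N)CC(=O)N[C@@H]1CCc2ccccc2N(Cc2ccc(-c3cccnc3-c3nn[nH]n3)cc2)C1=O` gives 2350 nM, and compound 3 `CC(C)(N)CC(=O)N[C@@H]1CCc2ccccc2N(Cc2ccc(-c3cscc3-c3nn[nH]n3)cc2)C1=O` gives 150 nM. The step of a 1.1-fold lower number from compound 1 to compound 2 (0.03 log units; within the scatter) lies within the scatter, whereas a 17-fold lower number from compound 1 to compound 3 (1.22 log units; beyond the scatter) and a 16-fold lower number from compound 2 to compound 3 (1.19 log units; beyond the scatter) are both large, so compound 3 stands alone at the lowest number of the three, well apart from the other two.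

Compound 4 `Cc1nnc(-c2cscc2-c2ccc(CN3C(=O)[C@H](NC(=O)CC(C)(C)N)CCc4ccccc43)cc2)o1` differs from compound 3 in one place: 5-methyl-1,3,4-oxadiazol-2-yl in place of 2H-tetrazol-5-yl on an aromatic carbon. Going by the values given here, no measured step exchanges this ring itself; the steps into compound 3 show only that changes at this part of the molecule can move this assay strongly, as a 16-fold lower number from compound 2 to compound 3 (1.19 log units; beyond the scatter) did. The pair that makes compound 3 stand out is being altered, so a move back toward higher numbers is expected rather than none, though its size is uncertain. Compound 4 is therefore expected to give about 1500 nM, within 300 nM to 8000 nM, an estimated step of a 10-fold higher number from compound 3 to compound 4 (1.00 log units; beyond the scatter).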

Compound 4, half-maximal effective concentration: 125 nM
The estimate for compound 4 lay 12-fold (1.08 log units) above the measured number, and the stated range ends above it.
By their numbers in this assay, from the lowest: compounds 4 and 3 (each within the scatter of the next); then compounds 2 and 1 (each within the scatter of the next).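

Exchanging 2H-tetrazol-5-yl for 5-methyl-1,3,4-oxadiazol-2-yl on the five-membered aromatic ring with 1 sulfur gives, in this assay, a 1.2-fold lower number from compound 3 to compound 4 (0.08 log units; within the scatter), so at this place a ring with 1 hydrogen-bond donor and a ring with 0 hydrogen-bond donors read alike. The low numbers therefore do not belong to the 2H-tetrazol-5-yl ring alone, since the 4-(5-methyl-1,3,4-oxadiazol-2-yl)thiophen-3-yl group also gives a 19-fold lower number from compound 2 to compound 4 (1.27 log units; beyond the scatter) and a 20-fold lower number from compound 1 to compound 4 (1.30 log units; beyond the scatter). No supporting measurement accounts for this result.

The compounds shown leave open what the methyl group contributes, as the oxadiazole ring appears only with it. They also leave open whether a carboxylic acid or a primary amide on the same ring would read like these two groups in this assay.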